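The source may hold more compounds than are shown below. What is called first, only, known or untested is meant among the compounds shown, and "the series" means these compounds.

Compound 1 `CC(C)[C@H](NS(=O)(=O)c1cccc(C(=O)NO)c1)C(=O)Nc1ccccc1` gives 40500 nM in an ADME assay on isolated protein for inhibition of protein deacetylase HDAC6 (Homo sapiens), read by fluorescence, with stated times of 5 min and 30 min (a higher number here means a weaker inhibitor, a lower number a stronger inhibitor), the highest of the three numbers seen so far. Compound 3 `O=C(NO)c1cccc(S(=O)(=O)N[C@H](C(=O)NCc2ccccc2)c2ccccc2)c1` gives 34000 nM, which lies within the scatter of compound 1, while compound 2 `O=C(NO)c1cccc(S(=O)(=O)NCc2ccccc2)c1` gives 2600 nM, a value beyond the scatter of both. The step of a 13-fold higher number from compound 2 to compound 3 (1.12 log units; beyond the scatter) shows that adding a group to the carbon bound to the sulfonamide nitrogen raised the number sharply. Compound 4 `O=C(CNS(=O)(=O)c1cccc(C(=O)NO)c1)Nc1ccccc1` is compound 1 with hydrogen in place of isopropyl on a saturated chain carbon bound to a carbonyl carbon and a sulfonamide nitrogen. Within the data shown here, only the step from compound 2 to compound 3 bears on this change, and it runs the opposite way, so a fall in the number is expected in this assay. The expected step is a 2.7-fold lower number from compound 1 to compound 4 (0.43 log units; beyond the scatter). Compound 4 is therefore estimated at 15000 nM, with a range from 5000 nM to 45000 nM.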

Compound 4, half-maximal inhibitory concentration: 14100 nM
Compound 4: middle estimate off by 1.1-fold (0.03 log units), on the high side; low and high end bracket the measured number.
By their numbers in this assay, from the lowest: compound 2; then compound 4; then compounds 3 and 1 (each within the scatter of the next).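

In this assay the loss of isopropyl from this carbon gives a 2.9-fold lower number from compound 1 to compound 4 (0.46 log units; beyond the scatter) and so shows a fall in the number on removing a group, on a carbon bound to a carbonyl carbon and a sulfonamide nitrogen. The earlier step of a 13-fold higher number from compound 2 to compound 3 (1.12 log units; beyond the scatter) showed only a rise on adding a different group, benzylcarbamoyl, to a carbon in a different setting. Nothing shown explains why the number falls with this change.

A methyl group on this carbon could show whether a smaller chain already gives the lower number. On these data alone, how an amine or a carboxylic acid at this place would read remains open.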